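Compound 4 and the aromatic group on the nitrogen

The source may report more compounds than this note shows. Statements on the series, on what has been measured and on what is new or still open speak of the compounds shown alone.

Values from a functional assay on MGC-803 cells (Homo sapiens) for antiproliferative activity, read by MTT assay, with a stated time of 48 h; on this read-out lower numbers stand for stronger inhibition and higher numbers for weaker inhibition
Compound 1 `O=C(Nc1ccccc1)Nc1cccc(CNc2nccnc2Cl)c1` gives 16300 nM
Compound 2 `O=C(Nc1ccc(Cl)cc1)Nc1cccc(CNc2nccnc2Cl)c1` gives 4980 nM
Compound 3 `O=C(Nc1cccc(CNc2nccnc2Cl)c1)NC1CCCCC1` gives > 40000 nM, a limit

Compound 3 stands at the limit of > 40000 nM in this assay, at which 1 of the 3 values shown sits, so it has a limit and no number.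

Compound 4 `Cc1ccc(NC(=O)Nc2cccc(CNc3nccnc3Cl)c2)cc1` carries 4-methylphenyl in place of cyclohexyl on an amide-type nitrogen.

The nearest measured steps run the opposite way, towards cyclohexyl. Replacing phenyl gave an at least 2.4-fold higher number from compound 1 to compound 3 (0.38 log units; beyond the scatter), and replacing 4-chlorophenyl gave an at least 8.0-fold higher number from compound 2 to compound 3 (0.90 log units; beyond the scatter). A lower number in this assay is therefore expected on returning to an aromatic ring, by a step of at least modest size. Among the compounds with values here, the other step, a 3.3-fold lower number from compound 1 to compound 2 (0.51 log units; beyond the scatter), shows that a substituent on that ring can matter, but no methyl example has been measured. Compound 4 is therefore expected to fall roughly in the span set by the two aromatic compounds, though this is not certain.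

The estimated step is an at least 5.0-fold lower number from compound 3 to compound 4 (0.69 log units; beyond the scatter).

For compound 4 the estimated value is 8000 nM, with an expected range of 3500 nM to 18000 nM.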

Compound 4, half-maximal inhibitory concentration: 11900 nM
For compound 4 the middle estimate is 1.5-fold (0.17 log units) below the measured one; measured number inside the range.
By their numbers in this assay, from the lowest: compound 2; then compounds 4 and 1 (each within the scatter of the next). At a limit, above all of these: compound 3.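

In this assay, 4-methylphenyl in place of cyclohexyl on the amide-type nitrogen gives an at least 3.3-fold lower number from compound 3 to compound 4 (0.52 log units; beyond the scatter), so all three aromatic compounds shown lie clear of the cyclohexyl compound. The value of compound 3 is a limit and not a number, so this step has no exact size: the limit of > 40000 nM in this assay, at which 1 of the 4 values shown sits. On the aromatic ring, methyl in place of hydrogen gives a 1.4-fold lower number from compound 1 to compound 4 (0.14 log units; within the scatter), whereas methyl in place of chloro gives a 2.4-fold higher number from compound 2 to compound 4 (0.38 log units; beyond the scatter), so a substituent on that ring does not by itself set the number apart, and among the three aromatic compounds only the chloro of compound 2 does.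

On these data alone, whether trifluoromethyl, methoxy or nitrile on the ring would track chloro or methyl remains open. Also open, as far as these compounds go, is how a longer alkyl chain, or an aromatic ring bearing an amine, would behave on this nitrogen in this assay.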